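The compounds below may be only part of what the source reports. "The series", "measured", "known", "first", "only" and "open" are said of these compounds alone.

Measured so far in a functional assay on ileum for inhibition of histamine H1 receptor (Cavia porcellus); a lower number here means a stronger inhibitor, a higher number a weaker inhibitor:
compound 1, `CCCCCN1CCN(c2nc3ccccc3n2CCOCC)CC1`: 30 nM
compound 2, `CCOCCn1c(N2CCNCC2)nc2ccccc21`: 11 nM
compound 3, `CCOCCn1c(N2CCN(CC)CC2)nc2ccccc21`: 18 nM

All three share one core and differ only in what sits on the amine nitrogen in the ring. Compound 3 holds the second highest of the three numbers; its nearest neighbour is compound 2, with a 1.6-fold higher number from compound 2 to compound 3 (0.21 log units; within the scatter), and its furthest is compound 1, with a 1.7-fold lower number from compound 1 to compound 3 (0.22 log units; within the scatter). Both of these steps are within the scatter, so no order among compound 1, compound 2 and compound 3 can be read from them. Among the compounds with values here, only the step of a 2.7-fold lower number from compound 1 to compound 2 (0.44 log units; beyond the scatter) lies beyond the scatter, and that one does not touch compound 4.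

Compound 4, `CCCN1CCN(c2nc3ccccc3n2CCOCC)CC1`, has not yet been measured in this assay. Its difference from compound 3 is methyl in place of hydrogen on a saturated chain carbon, two bonds along the chain from an amine nitrogen in a ring, that is, ethyl becomes propyl on the amine nitrogen in the ring. Within the data shown here, the steps that bear on this are a 1.6-fold higher number from compound 2 to compound 3 (0.21 log units; within the scatter) and a 1.7-fold lower number from compound 1 to compound 3 (0.22 log units; within the scatter), both within the scatter: hydrogen, ethyl and pentyl on that nitrogen give numbers that are not separated by more than the scatter. Compound 4 is expected to fall between compound 3 and compound 1, with an expected step of a 1.2-fold higher number from compound 3 to compound 4 (0.09 log units; within the scatter), which is no step beyond the scatter. Compound 4 is therefore estimated to give 22 nM in this assay, with an expected range from 10 nM to 50 nM.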

Compound 4, half-maximal inhibitory concentration: 16 nM
Compound 4: middle estimate off by 1.4-fold (0.14 log units), on the high side; measured number inside the range.
By their numbers in this assay, from the lowest: compounds 2, 4, 3 and 1 (each within the scatter of the next, the first and the last beyond it).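

In this assay, ethyl to propyl on the amine nitrogen in the ring, a methyl in place of hydrogen on a saturated chain carbon, gives the smallest step in the series (a 1.1-fold lower number from compound 3 to compound 4 (0.05 log units; within the scatter)), so one added carbon at this place makes no readable difference. Propyl also stays within the scatter of both ends of the set, hydrogen (a 1.5-fold higher number from compound 2 to compound 4 (0.16 log units; within the scatter)) and pentyl (a 1.9-fold lower number from compound 1 to compound 4 (0.27 log units; within the scatter)), which leaves a 2.7-fold lower number from compound 1 to compound 2 (0.44 log units; beyond the scatter) as the only step on this nitrogen beyond the scatter and shows no graded dependence on chain length among the three alkyl compounds, only a separation between hydrogen and pentyl. No independent data bear on why this position tolerates these chains.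

From the compounds shown here alone, whether a chain longer than pentyl, a benzyl group or a chain ending in a carboxylic acid on this nitrogen would move the number further remains open. The rest of the shared core is the same in all four compounds, so these data say nothing about changes elsewhere on it.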